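From phenyl to 4-ethylphenyl on the shared core

A few compounds are considered here, and "the series" means these few. Any claim that something is new, unique, unknown or untested is made for them only; others in the source may bear on it.

Within the data shown here, in a functional assay on MGC-803 cells (Homo sapiens) for antiproliferative activity, read by CCK-8 assay, with a stated time of 72 h (on this read-out higher numbers stand for weaker inhibition and lower numbers for stronger inhibition), compound 2 `Nc1ccccc1NC(=O)c1ccc(COc2ccccc2)cc1` gives 5670 nM, the only exact number so far. Compound 1 `Nc1ccccc1NC(=O)c1ccc(COc2ccc(Br)cc2)cc1` reads > 32000 nM, which is a limit of the assay and not a number. Compound 3 `CCc1ccc(OCc2ccc(C(=O)Nc3ccccc3N)cc2)cc1` keeps the core of compound 2 with one change, ethyl in place of hydrogen on an aromatic carbon, para to a large group. Among the measured compounds shown here, one measured step bears on this, since compound 1 carries bromo on that same carbon. Removing it gives an at least 5.6-fold lower number from compound 1 to compound 2 (0.75 log units; beyond the scatter), a step beyond the scatter. Read backwards, a group on that carbon went with weaker inhibition, though ethyl is not bromo and this is a single pair. The expected change is therefore a 3.0-fold higher number from compound 2 to compound 3 (0.48 log units; beyond the scatter), towards weaker inhibition in this assay. The estimate for compound 3 is 17000 nM, with an expected range of 6000 nM to 48000 nM.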

Compound 3, half-maximal inhibitory concentration: 5880 nM
The estimate for compound 3 lay 2.9-fold (0.46 log units) above the measured number; the measured number lies below the stated range.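

In this assay, a group on this carbon does not by itself go with weaker inhibition: ethyl in place of hydrogen gives a 1.0-fold higher number from compound 2 to compound 3 (0.02 log units; within the scatter) and leaves the two compounds indistinguishable. Ethyl in place of bromo instead gives an at least 5.4-fold lower number from compound 1 to compound 3 (0.73 log units; beyond the scatter), so among these three compounds the earlier loss belongs to bromo and not to every group at this position. Compound 1 stands at a limit of the assay and not at a number: the limit of > 32000 nM in this assay, at which 1 of the 3 values shown sits.

The compounds shown carry only hydrogen, bromo and ethyl on this carbon, so it remains open where an amine, a carboxylic acid or a methoxy group would fall. On these data alone, it is also open whether a longer chain in place of ethyl would leave the read-out as unchanged as ethyl did.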